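The source may hold more compounds than are shown below. What is called first, only, known or untested is meant among the compounds shown, and "the series" means these compounds.

The shared core carries a thioether chain ending in a carbonyl; compound 1 `COc1cc(-c2nnc(SCC(=O)c3ccc(Br)cc3)n2N)cc(OC)c1OC`, compound 2 `COc1cc(-c2nnc(SCC(=O)c3ccccc3F)n2N)cc(OC)c1OC` and compound 3 `COc1ccc(C(=O)CSc2nnc(-c3cc(OC)c(OC)c(OC)c3)n2N)cc1` differ only in the aryl on that carbonyl carbon. In a functional assay on HepG2 cells (Homo sapiens) for antiproliferative activity, read by MTT assay, with a stated time of 48 h (on this read-out lower numbers stand for stronger inhibition and higher numbers for weaker inhibition), compound 1 gives 92500 nM and compound 2 gives 22600 nM. For compound 3 the read-out in this assay is a limit of the assay, > 100000 nM. Compound 3 is set apart from compound 2 by an at least 4.4-fold higher number from compound 2 to compound 3 (0.64 log units; beyond the scatter), whereas the step of an at least 1.0-fold higher number from compound 1 to compound 3 (0.03 log units; that floor lies within the scatter) does not separate it from compound 1.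

Compound 4 `COc1cc(-c2nnc(SCC(=O)Nc3ccccc3)n2N)cc(OC)c1OC` arises from compound 3 by anilino in place of 4-methoxyphenyl on a carbonyl carbon. For the measured compounds named here, every measured step swaps one aryl for another on the carbonyl carbon, the largest being a 4.1-fold lower number from compound 1 to compound 2 (0.61 log units; beyond the scatter); none replaces a ketone with an amide, so the new step has no direct precedent. Given that aryl swaps moved the number only modestly, the expected step of an at least 1.1-fold lower number from compound 3 to compound 4 (0.04 log units; that floor lies within the scatter) is kept small. Compound 4 is therefore expected to give about 90000 nM in this assay, between 25000 nM and 300000 nM, with a real chance that only a limit results because the limit of > 100000 nM in this assay, at which 1 of the 3 values shown sits, already holds one of three values.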

Compound 4, half-maximal inhibitory concentration: 49900 nM
The estimate for compound 4 lay 1.8-fold (0.26 log units) above the measured number; measured number inside the range.
By their numbers in this assay, from the lowest: compound 2; then compounds 4 and 1 (each within the scatter of the next). At a limit, above all of these: compound 3.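

On the carbonyl carbon, anilino is the first group shown that is not an aryl, and in this assay it cannot be told apart from 4-bromophenyl: a 1.9-fold lower number from compound 1 to compound 4 (0.27 log units; within the scatter). It does not match 2-fluorophenyl, the step being a 2.2-fold higher number from compound 2 to compound 4 (0.34 log units; beyond the scatter), so compound 2 remains the most potent of the four. Against 4-methoxyphenyl only a floor can be read, an at least 2.0-fold lower number from compound 3 to compound 4 (0.30 log units; that floor lies within the scatter), and the value of compound 3 is a limit of the assay: the limit of > 100000 nM in this assay, at which 1 of the 4 values shown sits.

Open, on these data alone, is whether the amide hydrogen matters, a question that a methyl on the amide nitrogen would address. Also open, as far as these compounds go, is whether the 2-fluorophenyl result carries over to the amide series as 2-fluoroanilino, or whether a saturated amine such as piperidine on the carbonyl carbon would serve as well as anilino.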